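The source may report more compounds than this note shows. Statements on the series, on what has been measured and on what is new or still open speak of the compounds shown alone.

Measured compounds:
- compound 1 `CNc1nc(NCc2ccc(NC(C)=O)cc2)cc(-c2ccccn2)n1`: 5 nM
- compound 2 `Cc1nc(NCc2ccc(Cl)cc2)cc(-c2ccccn2)n1`: 81 nM
- compound 3 `CNc1nc(NCC2CCCCC2)cc(-c2ccccn2)n1`: 11 nM

All three were tested in a functional assay on HEK293 cells for agonist activity at G-protein coupled receptor 39 (Homo sapiens), read by inositol phosphate accumulation; on this read-out lower numbers stand for an effect already at smaller amounts and higher numbers for an effect only at larger amounts of compound. Compound 1 gives the lowest number of the three; compound 3 comes nearest to it, and that gap is already beyond the usual scatter, while compound 2 stands furthest away, with a gap well beyond the scatter. Compound 1 is therefore the most potent of the measured set in this assay.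

The next compound, compound 4 `CNc1nc(NCc2ccc(NS(C)(=O)=O)cc2)cc(-c2ccccn2)n1`, has not yet been measured. It differs from compound 1 in a single place: methylsulfonyl in place of acetyl on a nitrogen on an aromatic ring. Beyond that exchange, the rest of the molecule is the same as in compound 1.

Among the compounds with values here, no pair of measured compounds shows this particular exchange, so there is no measured step to lean on. Given that compound 1 sits at 5 nM in this assay, and that the change is confined to one group on the shared core, compound 4 is expected to stay close to its parent, with a step from compound 1 to compound 4 of a 1.6-fold higher number from compound 1 to compound 4 (0.20 log units; within the scatter), that is, no change beyond the scatter, leaning if anything toward a slightly higher number. On that basis compound 4 is estimated at 8 nM, within a range from 2 nM to 30 nM.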

Compound 4, half-maximal effective concentration: 3 nM
Beside the measured number, compound 4's estimate is 2.7-fold (0.43 log units) above it; the measured number falls inside the stated range.
By their numbers in this assay, from the lowest: compounds 4 and 1 (each within the scatter of the next); then compound 3; then compound 2.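

In this assay, putting methylsulfonyl in place of acetyl on a nitrogen on an aromatic ring gives a 1.7-fold lower number from compound 1 to compound 4 (0.22 log units; within the scatter) and so leaves the number unchanged within the usual scatter. Within the data shown here, this is the first pair here that differs in one place only, and it shows that this spot on the shared core tolerates an exchange of acetamido to methanesulfonamido: a group with one more heavy atom, a sulfur in place of a carbon at the centre and one more hydrogen-bond acceptor fits without any measurable loss. Nothing shown explains why the two groups read alike in this assay.

Still open, on these data alone, is how much further this nitrogen can be varied, for instance with ethylsulfonyl or a longer chain on the sulfonyl, or with a plain amine in place of the whole acetamido. Also open, as far as these compounds go, is whether the same exchange would read alike on a different background, such as with a methyl group in place of the methylamino group of the shared core.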